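Series notes: hydrogen for anilino on the amide nitrogen

The source may report more compounds than this note shows. Statements on the series, on what has been measured and on what is new or still open speak of the compounds shown alone.

Of the compounds shown here, three have been measured in a functional assay on CHO cells for agonist activity at adenosine receptor A1 (Homo sapiens), read by ERK phosphorylation, tested at 3 uM; on this read-out higher numbers stand for a stronger effect at the one concentration tested and lower numbers for a weaker effect. Compound 1 `NNC(=O)c1c(N)sc2c1CCCCC2` gives 52% in this assay. Compound 2 `Nc1sc2c(c1C(=O)NNc1ccccc1)CCCCCC2` gives 47%, and compound 3 `Nc1sc2c(c1C(=O)NCc1cccc(Cl)c1)CCCCCC2` gives 49%. Compound 2 holds the lowest of the three numbers, but the nearest of the others, compound 3, lies within the scatter of it, and so does the furthest, compound 1; no order among the three can be read from these values.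

Compound 4 `NC(=O)c1c(N)sc2c1CCCCCC2` has not yet been measured in this assay. It differs from compound 2 in one place: hydrogen in place of anilino on an amide-type nitrogen. For the measured compounds named here, no step between measured compounds is on record for this or any other change, so nothing anchors its size. The three measured values all sit within the scatter of one another despite different groups on the amide nitrogen. The expectation for compound 4 is therefore a step of a number 3 percentage points higher from compound 2 to compound 4 (within the scatter) of no size beyond the scatter. Compound 4 is estimated at 50% in this assay, with a range from 35% to 65%.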

Compound 4, a percentage reported as activity, at one concentration (the size of the read-out at that concentration, not a potency): 48%
For compound 4 the middle estimate is 2 percentage points above the measured one; the measured number falls inside the stated range.
By their numbers in this assay, from the lowest: compounds 2, 4, 3 and 1 (each within the scatter of the next).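

Replacing anilino with hydrogen on the amide-type nitrogen gives the series its first one-place step, and in this assay it reads a number 1 percentage points higher from compound 2 to compound 4 (within the scatter). At the one concentration tested, the effect of compound 2 therefore does not depend on the anilino group and its six-membered aromatic ring, since compound 4 keeps the read-out within the scatter with only hydrogen at this place. No measurement on record bears on why this change leaves the read-out unmoved.

As far as these compounds go, whether any group on this nitrogen can move the number beyond the scatter remains open, with a methyl group, a longer alkyl chain or an aminoethyl chain as untested cases. A single-concentration read-out also cannot show whether compound 2 and compound 4 would stay together across a range of concentrations.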